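Swapping the Ring on the Sulfonamide Nitrogen

The source may report more compounds than this note shows. Statements on the series, on what has been measured and on what is new or still open speak of the compounds shown alone.

Three compounds share one core and differ only in the group carried on a sulfonamide nitrogen. Compound 1 `CC(=O)NS(=O)(=O)c1ccc(N/C=C\C(=O)c2cc3ccccc3oc2=O)cc1` shows no result reported in a functional assay on T47D cells (Homo sapiens) for cytotoxicity, read by sulforhodamine B assay, with a stated time of 48 h; a lower number here means a stronger inhibitor, a higher number a weaker inhibitor. Compound 2 `Cc1noc(NS(=O)(=O)c2ccc(N/C=C\C(=O)c3cc4ccccc4oc3=O)cc2)c1C` gives 68400 nM in this assay. Compound 3 `O=C(/C=C\Nc1ccc(S(=O)(=O)Nc2ccccn2)cc1)c1cc2ccccc2oc1=O` gives 37600 nM in this assay, the lowest of the two available numbers, but the step of a 1.8-fold lower number from compound 2 to compound 3 (0.26 log units; within the scatter) is too small to count as a real difference, so the two compounds are effectively level.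

Compound 4 `Cc1cc(C)nc(NS(=O)(=O)c2ccc(N/C=C\C(=O)c3cc4ccccc4oc3=O)cc2)n1` is the next member, and the change from compound 3 is 4,6-dimethylpyrimidin-2-yl in place of pyridin-2-yl on a sulfonamide nitrogen. Among the measured compounds shown here, the only measured step that speaks to this position, the step from compound 2 to compound 3, exchanged one aromatic ring on that nitrogen for another and moved the number by less than the usual scatter. On that evidence the ring on the sulfonamide nitrogen has, so far, made little difference to this readout.

The expectation for compound 4 is therefore no step beyond the scatter, a change of about a 1.1-fold higher number from compound 3 to compound 4 (0.05 log units; within the scatter) in this assay. Compound 4 is estimated at 42000 nM, with a plausible range from 15000 nM to 110000 nM.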

Compound 4, half-maximal inhibitory concentration: 62200 nM
The estimate for compound 4 lay 1.5-fold (0.17 log units) below the measured number, within the range that was stated.
By their numbers in this assay, from the lowest: compounds 3, 4 and 2 (each within the scatter of the next).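

Exchanging pyridin-2-yl for 4,6-dimethylpyrimidin-2-yl on the sulfonamide nitrogen adds two methyl groups and a second hetero atom to the ring, yet in this assay this gives only a 1.7-fold higher number from compound 3 to compound 4 (0.22 log units; within the scatter) and so no real difference. Replacing 3,4-dimethyl-1,2-oxazol-5-yl with the same group gives a 1.1-fold lower number from compound 2 to compound 4 (0.04 log units; within the scatter), so all three compounds with a number now stand level, and the flat result seen earlier for a single exchange also holds for these two further pairings of rings. No measurement at hand explains why these exchanges leave the number unmoved.

Steps involving compound 1, which carries an acetyl group on that nitrogen, cannot be read, since it has no number to compare. Still open, from the compounds shown here alone, is whether a group of a different kind on the sulfonamide nitrogen, such as a plain methyl, a cyclohexyl ring, or an aromatic ring bearing an amine or a carboxylic acid, would shift the number beyond the scatter.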